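Swapping Methyl for Chloro on a Pyridinium-Tethered Core

This account rests on a few compounds, and the source may have more. Where it says the series, first, only, none or still open, it means among the compounds named here.

Measured compounds:
compound 1, `Cc1cc(-n2cc(C(=O)Nc3cc(F)cc(F)c3)c(=O)c3ccc(N(C)C)nc32)ccc1OCCCCCCC[n+]1ccccc1`: "not active" (no number reported)
compound 2, `CC[N+]1(CCCCCCCOc2ccc(-n3cc(C(=O)Nc4cc(F)cc(F)c4)c(=O)c4ccc(N(C)C)nc43)cc2C)CCCCC1`: 19.7%

Among the compounds with values here, in an assay on LX2 cells for inhibition of COL1A1 promoter (Homo sapiens), read by a luciferase reporter, with a stated time of 24 h, tested at 20 uM (on this read-out higher numbers stand for a stronger effect at the one concentration tested and lower numbers for a weaker effect), compound 2 gives 19.7%, the only number in this set. Within the data shown here, compound 1 is reported as "not active" (no number reported) without a number, so no step between measured compounds can be drawn.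

Compound 3 is `CC[N+]1(CCCCCCCOc2ccc(-n3cc(C(=O)Nc4cc(F)cc(F)c4)c(=O)c4ccc(N(C)C)nc43)cc2Cl)CCCCC1`. It differs from compound 2 by chloro in place of methyl on an aromatic carbon. Among the measured compounds shown here, with no measured step of this kind to lean on, the change is expected to stay within the usual scatter, a number 2.3 percentage points higher from compound 2 to compound 3 (within the scatter). Compound 3 is therefore expected to give 22%, with a likely range from 5% to 40%.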

Compound 3, a percentage reported as inhibition, at one concentration (the size of the read-out at that concentration, not a potency): 14.3%
Compound 3: middle estimate off by 7.7 percentage points, on the high side; the range from low to high includes it.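

In this assay, chloro in place of methyl gives a number 5.4 percentage points lower from compound 2 to compound 3 (within the scatter), so the two groups cannot be told apart on this read-out. Within the data shown here, on this aromatic carbon, ortho to a large group and meta to a large group, this one-atom swap therefore gives the first comparison between measured compounds, and its size stays within what repeat measurements would show. No measured information here explains the result.

On these data alone, whether fluoro, methoxy or a plain hydrogen on this carbon would give a step beyond the scatter remains open. Each compound is read at one concentration only, so these numbers show the size of the effect at that concentration and nothing about the effect at any other.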